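The source may hold more compounds than are shown below. What is called first, only, known or untested is meant among the compounds shown, and "the series" means these compounds.

Measured in a functional assay on HL-60 cells (Homo sapiens) for antiproliferative activity, read by MTT assay, with a stated time of 72 h; on this read-out lower numbers stand for stronger inhibition and higher numbers for weaker inhibition:
- compound 1 `CC(C)(C)c1ccc(OCCCON2C(N)=NC(N)=NC23CCSCC3)cc1`: 280 nM
- compound 2 `NC1=NC2(CCSCC2)N(OCCCOc2cccc(Cl)c2)C(N)=N1`: 260 nM

Only these two numbers are available so far. They lie within the usual scatter of each other, so compound 2 at 260 nM cannot be ranked apart from compound 1 at 280 nM.

Compound 3 `NC1=NC2(CCSCC2)N(OCCCOc2cccc(Cl)c2Cl)C(N)=N1` has not yet been measured in this assay. It differs from compound 2 in a single place: chloro in place of hydrogen on an aromatic carbon. In words, this is chloro in place of hydrogen on an aromatic carbon, which turns 3-chlorophenyl into 2,3-dichlorophenyl. The new chloro stands ortho to a chloro group and ortho to a large group.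

For the measured compounds named here, no measured pair shows this change directly, so any forecast is uncertain. Still, the aromatic ring carries different groups in compound 1 at 280 nM and compound 2 at 260 nM, and the two values stay within the scatter. A small step is therefore expected, leaning slightly towards stronger inhibition and probably not beyond the scatter. The expected change is a 1.3-fold lower number from compound 2 to compound 3 (0.11 log units; within the scatter). For compound 3 the estimated value is 200 nM, with an expected range from 70 nM to 550 nM.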

Compound 3, half-maximal inhibitory concentration: 30 nM
Beside the measured number, compound 3's estimate is 6.7-fold (0.82 log units) above it; measured number below the stated range.
By their numbers in this assay, from the lowest: compound 3; then compounds 2 and 1 (each within the scatter of the next).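

In this assay, adding a single chloro to the aromatic ring, which turns 3-chlorophenyl into 2,3-dichlorophenyl, gives an 8.7-fold lower number from compound 2 to compound 3 (0.94 log units; beyond the scatter). The earlier compounds shown here included no pair that tested this position, and this step shows that the position, ortho to a chloro group and ortho to a large group, is sensitive to substitution: one heavy atom, with no ring, no hydrogen-bond donors or acceptors and no net charge, is enough to move the number well beyond the scatter. Nothing measured here accounts for the size of this step.

From the compounds shown here alone, it remains open whether this gain is specific to chloro or would also appear with another group at the same position, such as fluoro, methyl or methoxy. Also unresolved is whether the new chloro would have a similar effect without the existing chloro group on the ring, and whether the same change would give a comparable step on the differently substituted ring of compound 1.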